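This account rests on a few compounds, and the source may have more. Where it says the series, first, only, none or still open, it means among the compounds named here.

Of the compounds shown here, three have already been measured in a functional assay on HT-29 cells (Homo sapiens) for inhibition, read by MTT assay, with a stated time of 48 h; on this read-out higher numbers stand for weaker inhibition and lower numbers for stronger inhibition. Compound 1 `Cc1ccc(COc2ccc(C(=O)NC(=S)Nc3ccc(C)c(-c4nc5ccccc5[nH]4)c3)cc2)cc1` gives 14200 nM, and compound 2 `Cc1ccc(NC(=S)NC(=O)c2ccc(OCc3cccc(F)c3)cc2)cc1-c1nc2ccccc2[nH]1` gives 55300 nM. Going by the values given here, the only change between them is 3-fluorophenyl in place of 4-methylphenyl on a saturated chain carbon bound to an oxygen on an aromatic ring, and it made a 3.9-fold higher number from compound 1 to compound 2 (0.59 log units; beyond the scatter). Compound 3 `Cc1ccc(COc2ccc(C(=O)NC(=O)Nc3ccc(C)c(-c4nc5ccccc5[nH]4)c3)cc2)cc1` gives 5110 nM, the lowest of the three numbers; the difference between the core of compound 1 and the core of compound 3 is not broken down here.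

Compound 4 `Cc1ccc(NC(=O)NC(=O)c2ccc(OCc3cccc(F)c3)cc2)cc1-c1nc2ccccc2[nH]1` has not yet been measured. It differs from compound 3 by 3-fluorophenyl in place of 4-methylphenyl on a saturated chain carbon bound to an oxygen on an aromatic ring, the same change at the same place as between compound 1 and compound 2. Among the compounds with values here, since the only measured example of this change is a 3.9-fold higher number from compound 1 to compound 2 (0.59 log units; beyond the scatter), a step of similar size is expected here, namely a 3.7-fold higher number from compound 3 to compound 4 (0.57 log units; beyond the scatter). Compound 4 is therefore expected to give about 19000 nM, with 8000 nM to 45000 nM as the likely range.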

Compound 4, half-maximal inhibitory concentration: 38200 nM
For compound 4 the middle estimate is 2.0-fold (0.30 log units) below the measured one, and the stated range covers the measured number.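

Putting 3-fluorophenyl in place of 4-methylphenyl in this assay again weakens inhibition, with a 7.5-fold higher number from compound 3 to compound 4 (0.87 log units; beyond the scatter) on the core of compound 3. The change therefore carries over in the same direction, and the two steps cannot be told apart in size: the same change on two cores in this assay, a 3.9-fold higher number (0.59 log units; beyond the scatter) from compound 1 to compound 2 and a 7.5-fold higher number (0.87 log units; beyond the scatter) from compound 3 to compound 4, 1.9-fold (0.28 log units) apart, within the scatter of two such steps. Going by these compounds alone, these are only two pairs in one assay, so they do not show that the change would behave alike on a third core, and they do not show what lies behind it.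

The compounds shown leave open how an unsubstituted phenyl or a carboxylic acid would read at this place. They also leave open what a longer chain between the oxygen and the ring would do on either core.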